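Cytotoxicity notes: 4-methylphenoxy to 4-chlorophenoxy

The source may hold more compounds than are shown below. What is called first, only, known or untested is meant among the compounds shown, and "the series" means these compounds.

Going by the values given here, in an ADME assay on HEK-293T cells (Homo sapiens) for cytotoxicity, read by MTT assay, with a stated time of 48 h (on this read-out higher numbers stand for an effect only at larger amounts of compound and lower numbers for an effect already at smaller amounts), compound 1 `Cc1ccc(Oc2ccc(/C=C3\Oc4cc(O)ccc4C3=O)cc2)cc1` gives 95000 nM, the only actual number so far. Compound 2 `O=C1/C(=C/c2cccc(-c3cccc(-c4cnc5ccccc5c4)c3)c2)Oc2ccccc21` gives > 100000 nM, which is a limit of the assay and not a number. Compound 3 `O=C1/C(=C/c2ccc(Oc3ccc(Cl)cc3)cc2)Oc2cc(O)ccc21` carries chloro in place of methyl on an aromatic carbon, para to a large group (chloro in place of methyl on an aromatic carbon). Among the compounds with values here, no measured step bears on this change, so with compound 1 at 95000 nM as the sole anchor, no shift beyond the scatter is expected in this assay, in either direction. The expected change is a 1.1-fold lower number from compound 1 to compound 3 (0.05 log units; within the scatter). For compound 3 the estimated value is 85000 nM, with an expected range of 40000 nM to 100000 nM.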

Compound 3, half-maximal effective concentration: 12000 nM
For compound 3 the middle estimate is 7.1-fold (0.85 log units) above the measured one, and the stated range ends above it.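

In this assay, chloro in place of methyl on an aromatic carbon, para to a large group, gives a 7.9-fold lower number from compound 1 to compound 3 (0.90 log units; beyond the scatter), so this position responds to a one-atom exchange. The value of compound 1 lies close to the ceiling of the read-out, so a shift at this position could be resolved clearly only towards lower numbers: the limit of > 100000 nM in this assay, at which 1 of the 3 values shown sits.

Going by these compounds alone, whether the shift is specific to chloro stays open, as one pair gives only one step. Bromo, methoxy or an amine at this position would show whether other groups move the value similarly.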